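Hydroxy to Methoxy on the Core of Compound 3

The compounds below may be only part of what the source reports. "The series", "measured", "known", "first", "only" and "open" are said of these compounds alone.

Measured so far in a functional assay on A549 cells (Homo sapiens) for cytotoxicity, read by MTT assay, with a stated time of 6 days; a lower number here means that less compound is needed, a higher number that more compound is needed for the effect:
compound 1 `COC(=O)c1c(-c2cc(OC)cc(OC)c2)oc2ccccc2c1=O` gives the limit > 25 ug/mL.
compound 2 `COc1cc(OC)cc(-c2oc3ccccc3c(=O)c2C(=O)O)c1` gives the limit > 25 ug/mL.
compound 3 `COc1cc(-c2cc(=O)c3cc(O)ccc3o2)cc(OC)c1OC` gives 9.82 ug/mL.

Compound 1 and compound 2 both sit at the limit of > 25 ug/mL in this assay, at which 2 of the 3 values shown sit, so the change methyl in place of hydrogen on an oxygen next to a carbonyl group produced a step that the two limits leave unreadable from compound 2 to compound 1. Compound 4 `COc1ccc2oc(-c3cc(OC)c(OC)c(OC)c3)cc(=O)c2c1` differs from compound 3 by methyl in place of hydrogen on an oxygen on an aromatic ring. This is the same kind of change, not the same: in compound 2 the place is an oxygen next to a carbonyl group whose other neighbour is a carbonyl carbon, in compound 3 an oxygen on an aromatic ring whose other neighbour is an aromatic carbon. The difference between the two cores is not broken down here. Because compound 3 gives 9.82 ug/mL and the earlier step is unreadable, the step from compound 3 to compound 4 is expected to be a 1.2-fold higher number from compound 3 to compound 4 (0.09 log units; within the scatter). Compound 4 is estimated at 12 ug/mL, between 4 ug/mL and 30 ug/mL.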

Compound 4, concentration for half-maximal effect: > 25 ug/mL
Compound 4 gave a limit, no number (the forecaster's own chance of this, stated with the estimate: 30%); middle value at least 2.0-fold (0.31 log units) from the limit.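

In this assay, going from hydroxy to methoxy on the core of compound 3 gives an at least 2.5-fold higher number from compound 3 to compound 4 (0.40 log units; beyond the scatter), so on this core more compound is needed for the effect. Going by these compounds, compound 4 gives only a limit, > 25 ug/mL, so the full size of this step remains unknown. The related change on the other core cannot be read, since compound 1 and compound 2 both give limits, so these data do not show whether the effect carries from one core to the other: the limit of > 25 ug/mL in this assay, at which 3 of the 4 values shown sit.

The compounds shown leave open how an amine in place of the hydroxy, or a longer chain on that oxygen, would read in this assay. Also open, on these data alone, is how hydroxy to methoxy behaves on any further core.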